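Adding Trifluoromethyl to a Potent Anilide

The compounds below may be only part of what the source reports. "The series", "measured", "known", "first", "only" and "open" are said of these compounds alone.

Among the compounds with values here, in a functional assay on MDA-MB-468 cells (Homo sapiens) for cytotoxicity, read by sulforhodamine B assay, with a stated time of 48 h (on this read-out higher numbers stand for weaker inhibition of growth and lower numbers for stronger inhibition of growth), compound 1 `Nc1c(C(=O)Nc2ccccc2)sc2nc3c(cc12)CCCCCC3` gives 291 nM, the lowest of the two numbers measured so far. Compound 2 `Nc1c(C(=O)Nc2ccccc2Cl)sc2nc3c(cc12)CCCCCC3`, which carries chloro in place of hydrogen on an aromatic carbon, gives 2250 nM. Compound 3 `Nc1c(C(=O)Nc2cccc(C(F)(F)F)c2)sc2nc3c(cc12)CCCCCC3` instead has trifluoromethyl in place of hydrogen on an aromatic carbon, meta to a large group. Within the data shown here, the only measured guide is a 7.7-fold higher number from compound 1 to compound 2 (0.89 log units; beyond the scatter), a single step made with a different group. A smaller rise in the same direction is therefore expected, a 2.2-fold higher number from compound 1 to compound 3 (0.35 log units; beyond the scatter). For compound 3, the estimated value is 650 nM, with an expected range of 170 nM to 2500 nM.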

Compound 3, concentration for 50% growth inhibition: 798 nM
The estimate for compound 3 lay 1.2-fold (0.09 log units) below the measured number; measured number inside the range.
By their numbers in this assay, from the lowest: compound 1; then compound 3; then compound 2.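

Trifluoromethyl on this six-membered aromatic ring, meta to a large group, also weakens growth inhibition in this assay, with a 2.7-fold higher number from compound 1 to compound 3 (0.44 log units; beyond the scatter) as the step. A second replacement of hydrogen on this ring, with a different group on a different carbon, therefore moves the number in the same direction as chloro, and compound 1, with neither group, still has the lowest number. No measurement shown explains this rise. As far as these compounds go, whether an amine or a methoxy group on this same carbon would bring the number closer to that of compound 1 remains open.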